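The compounds below may be only part of what the source reports. "The series", "measured", "known", "first", "only" and "open" are said of these compounds alone.

In an ADME assay on MDCK cells (Canis lupus familiaris) for cytotoxicity, read by microscopy, with a stated time of 48 h (a higher number here means that more compound is tolerated, a lower number that less compound is tolerated), compound 1 `C[C@H]1[C@H](NCc2sccc2Br)C[C@H]2C[C@@H]1C2(C)C` gives 50000 nM. Compound 2 `CCOc1ccsc1CN[C@@H]1C[C@H]2C[C@@H]([C@H]1C)C2(C)C` gives 50000 nM and stands level with compound 1, the two together being the highest of the three numbers. Compound 3 `C[C@H]1[C@H](NCc2cc(Br)cs2)C[C@H]2C[C@@H]1C2(C)C` gives 6250 nM, the lowest of the three. Compound 4 `CCc1ccsc1CN[C@@H]1C[C@H]2C[C@@H]([C@H]1C)C2(C)C` differs from compound 2 by ethyl in place of ethoxy on an aromatic carbon. Two measured steps can be weighed against this change. The step of no change at the digits printed from compound 1 to compound 2 (within the scatter) concerns the same aromatic carbon that compound 4 alters and shows that exchanging one group for another there left the read-out unmoved. The step of an 8.0-fold lower number from compound 1 to compound 3 (0.90 log units; beyond the scatter) concerns where the bromo sits on the ring rather than what group sits on this carbon, so it bears less on the present case. Compound 4 is therefore expected to show the step of no change at the digits printed from compound 2 to compound 4 (within the scatter), that is, nothing beyond the scatter, because the step of no change at the digits printed from compound 1 to compound 2 (within the scatter) was already flat. Compound 4 is estimated at 50000 nM, with a range from 12500 nM to 100000 nM.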

Compound 4, minimum cytotoxic concentration: 25000 nM
Estimate against measurement, compound 4: 2.0-fold (0.30 log units) above; the range from low to high includes it.
By their numbers in this assay, from the lowest: compound 3; then compounds 4, 1 and 2 (each within the scatter of the next).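

In this assay the step of a 2.0-fold lower number from compound 2 to compound 4 (0.30 log units; within the scatter) shows that this aromatic carbon, two ring bonds from the ring sulfur, also takes ethyl, which has no hydrogen-bond acceptor, without the read-out leaving the scatter. Within the data shown here, with the step of a 2.0-fold lower number from compound 1 to compound 4 (0.30 log units; within the scatter) in addition, bromo, ethoxy and ethyl now form a set of three groups at this carbon whose numbers lie within the scatter of the next, whereas the earlier compounds offered only a single pair. Nothing measured here accounts for this flatness.

The compounds shown leave open whether an amine or a carboxylic acid on this carbon would stay within the scatter as well, and whether a chain longer than ethoxy would. They also leave open whether ethyl would match bromo at the ring place that sets compound 3 apart.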